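Replacing the Sulfonyl Group on the Amine Nitrogen

A few compounds are considered here, and "the series" means these few. Any claim that something is new, unique, unknown or untested is made for them only; others in the source may bear on it.

Compound 1: `CC(=O)c1ccc(S(=O)(=O)N[C@@H](C)Cn2ccc(-c3ccc(C#N)c(Cl)c3)n2)cc1`, > 30000 nM
Compound 2: `C[C@@H](Cn1ccc(-c2ccc(C#N)c(Cl)c2)n1)NS(=O)(=O)c1cn(C)cn1`, > 30000 nM
Compound 3: `C[C@@H](Cn1ccc(-c2ccc(C#N)c(Cl)c2)n1)Nc1ccc2ccccc2n1`, > 30000 nM

In an ADME assay on PC-3 cells (Homo sapiens) for cytotoxicity, read by CCK-8 assay, with a stated time of 6 days (a lower number here means a stronger inhibitor, a higher number a weaker inhibitor), compound 2 gives > 30000 nM, which is a limit of the assay and not a number. Compound 1 also gives only a limit, > 30000 nM. Compound 3 likewise gives only a limit, > 30000 nM. Among the measured compounds shown here, all three values shown therefore sit at the limit of > 30000 nM in this assay, at which 3 of the 3 values shown sit, and the one step that exists between measured compounds, a step that the two limits leave unreadable from compound 1 to compound 2, cannot be read in size or direction. For the measured compounds named here, compounds 2 and 3 share the same limit and no step between them is known.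

Compound 4, `C[C@@H](Cn1ccc(-c2ccc(C#N)c(Cl)c2)n1)Nc1ncnc2nc[nH]c12`, differs from compound 2 by a group of 9 heavy atoms (5 carbon, 4 nitrogen; one five-membered aromatic ring with 2 hetero atoms, one six-membered aromatic ring with 2 hetero atoms) in place of a group of 9 heavy atoms (4 carbon, 2 nitrogen, 2 oxygen, 1 sulfur; one five-membered aromatic ring with 2 hetero atoms), on an amine nitrogen. No measured step bears on this change; the only step shown is unreadable, and compound 3, which also carries a group on the amine nitrogen in place of a sulfonyl, stays at the limit. Compound 4 is therefore expected to remain at the limit as well, a step of a number no higher from compound 2 to compound 4 (the limit leaves the size open). The estimate for compound 4 is 30000 nM, ranging from 10000 nM to 90000 nM.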

Compound 4, half-maximal inhibitory concentration: 14100 nM
Beside the measured number, compound 4's estimate is 2.1-fold (0.33 log units) above it, within the range that was stated.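

In this assay, the group on the amine nitrogen proves able to shift the read-out, and the exchange of (1-methyl-1H-imidazol-4-yl)sulfonyl for the group with a five-membered and a six-membered aromatic ring gives an at least 2.1-fold lower number from compound 2 to compound 4 (0.32 log units; beyond the scatter). Losing the sulfonyl is not enough on its own: compound 3, which also has no sulfonyl on that nitrogen, gives > 30000 nM, a limit of the assay. Compound 4 is the only compound shown that gives a number rather than a limit: the limit of > 30000 nM in this assay, at which 3 of the 4 values shown sit.

From the compounds shown here alone, the full size of the step stays open, and so does whether the hydrogen-bond donor of the entering group has any part in it. How an acetyl group or a carboxylic acid on a longer chain at that nitrogen would read is also unknown.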